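A Fluoro Group Removed from Compound 2

The source may report more compounds than this note shows. Statements on the series, on what has been measured and on what is new or still open speak of the compounds shown alone.

- compound 1 `N#Cc1ccc(NC(=O)c2ccc(-c3cccnc3)cc2O)cc1` | 7940 nM
- compound 2 `N#Cc1ccc(NC(=O)c2c(O)cccc2F)cc1` | > 10000 nM (a limit)

In a functional assay on KG-1 cells (Homo sapiens) for cytotoxicity, read by luminescence and CellTiter-Glo, with a stated time of 3 days (on this read-out lower numbers stand for stronger inhibition and higher numbers for weaker inhibition), compound 1 gives 7940 nM as a measured number. Compound 2 reads > 10000 nM and this is a limit of the assay, not a number. Among the measured compounds shown here, compound 2 therefore has no exact place on the scale, and no pair of measured compounds differing in one place is available as a guide.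

Compound 3 `N#Cc1ccc(NC(=O)c2ccccc2O)cc1` has not yet been measured. It differs from compound 2 by one change, hydrogen in place of fluoro on an aromatic carbon. No measured step sizes this change in this assay and so no step beyond the usual scatter is expected, in either direction. The expectation starts from compound 2 and its reading of > 10000 nM as a limit, and compound 3 may likewise be reported only as a limit. The expected size of the change is a number no higher from compound 2 to compound 3 (the limit leaves the size open) on this estimate. Compound 3 is estimated at 10000 nM with an expected range from 4000 nM to 30000 nM in this measurement.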

Compound 3, half-maximal inhibitory concentration: 5370 nM
Compound 3: the middle estimate sits 1.9-fold (0.27 log units) above what was measured; the measured number falls inside the stated range.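

In this assay the exchange of fluoro for hydrogen, on the aromatic carbon ortho to a large group and meta to a hydroxy group, can now be read as a step: an at least 1.8-fold lower number from compound 2 to compound 3 (0.27 log units; that floor lies within the scatter), so this change gives compound 3 a measured number on the scale. Hydrogen in place of pyridin-3-yl on an aromatic carbon can be read as well, as a 1.5-fold lower number from compound 1 to compound 3 (0.17 log units; within the scatter), so removing that larger group from its own place brings no change beyond the scatter. The fluoro step remains only a floor, since the reading of compound 2 is a limit of the assay and not a number: the limit of > 10000 nM in this assay, at which 1 of the 3 values shown sits.

Going by these compounds, how far the step from fluoro to hydrogen truly reaches stays open, as does whether a chlorine, a methoxy group or an amine on the same aromatic carbon would move the number beyond the scatter. The compounds shown also leave open what a carboxylic acid in place of the nitrile would do in this assay, since that group stays the same throughout.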